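The compounds below may be only part of what the source reports. "The series", "measured", "known", "first", "only" and "open" are said of these compounds alone.

Two compounds of this series carry numbers in a functional assay for inhibition, with Rattus norvegicus as the target; a higher number here means a weaker inhibitor, a lower number a stronger inhibitor. Compound 1 `CC(/N=c1\c(O)c(O)\c1=N/c1cccc2cccnc12)C(C)(C)C` gives 8100 nM in this assay. Compound 2 `CC(C)C(C)/N=c1\c(O)c(O)\c1=N/c1ccc(C#N)cc1` gives 1900 nM in this assay, the lowest of the two numbers; the nearest number is that of compound 1, and the gap between the two lies beyond the scatter. Among the measured compounds shown here, compounds 1 and 2 differ from each other in more than one place, so their two values show only that compound 2 is the stronger inhibitor of the pair; no single-point step is on hand.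

Compound 3 `C[C@H](/N=c1\c(O)c(O)\c1=N/c1ccc(C#N)cc1)c1ccccc1` remains to be measured in this assay. Its difference from compound 2 is 1-phenylethyl in place of 1,2-dimethylpropyl on a double-bonded nitrogen. A six-membered aromatic ring enters on the double-bonded nitrogen where a branched chain without a ring stood before; donors, acceptors and charge do not change. For the measured compounds named here, no measured step speaks to this change, so no direction is backed by data. The step is expected to be small, of the order of a 1.3-fold lower number from compound 2 to compound 3 (0.10 log units; within the scatter), and not clearly beyond the scatter. For compound 3 the estimate is 1500 nM, within 400 nM to 6000 nM.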

Compound 3, half-maximal inhibitory concentration: > 30000 nM
Compound 3: only a limit was reported; the forecaster's own chance of this, stated with the estimate: 5%; at least 20-fold (1.30 log units) between middle value and limit.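

In this assay compound 3 gives > 30000 nM, which is a limit of the assay and not a number. Among the compounds shown here, this is the first single-point step, and it shows that the substituent on the double-bonded nitrogen is not a freely exchangeable part of the molecule: with the 4-cyanophenyl side and the shared core held constant, 1-phenylethyl in place of 1,2-dimethylpropyl gives an at least 15-fold higher number from compound 2 to compound 3 (1.19 log units; beyond the scatter), a large loss of inhibition that compound 1 and compound 2 alone could not reveal. The size of this step is a bound rather than a measured gap, so the true loss may be greater: the limit of > 30000 nM in this assay, at which 1 of the 3 values shown sits.

The compounds shown leave open whether the loss belongs to the six-membered aromatic ring, to the defined stereocentre of 1-phenylethyl, or to the larger count of heavy atoms in the entering group. A 1-cyclohexylethyl group, a benzyl group or the opposite stereoisomer of 1-phenylethyl on the double-bonded nitrogen would separate these three readings.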